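The compounds below may be only part of what the source reports. "The series", "measured", "known", "first", "only" and "open" are said of these compounds alone.

Compound 1 `O=C1C=C(Nc2ccccc2F)C(=O)c2c1nc1n2[C@H]2OC[C@@H](O)[C@H]2OC1` gives 3640 nM in a functional assay on MCF7 cells (Homo sapiens) for inhibition, read by sulforhodamine B assay; on this read-out higher numbers stand for weaker inhibition and lower numbers for stronger inhibition. Compound 2 `O=C1C(Nc2ccc(C(F)(F)F)cc2)=CC(=O)c2c1nc1n2[C@H]2OC[C@@H](O)[C@H]2OC1` gives only a limit, > 4000 nM, in this assay. Compound 3 `O=C1C(NC2CC2)=CC(=O)c2c1nc1n2[C@H]2OC[C@@H](O)[C@H]2OC1` likewise gives only a limit, > 16000 nM.

Among the compounds with values here, compound 1 therefore stands as the one compound with a number in this assay; the other two values are limits. Compound 4 `O=C1C=C(Nc2cccc(Cl)c2)C(=O)c2c1nc1n2[C@H]2OC[C@@H](O)[C@H]2OC1` differs from it by 3-chlorophenyl in place of 2-fluorophenyl on an amine nitrogen. Within the data shown here, the single measured step, a step that the two limits leave unreadable from compound 2 to compound 3, concerns a different change and cannot be read, so no measured step bears on the move from compound 1 to compound 4. With nothing to guide direction, compound 4 is expected to sit near compound 1, the step of a 1.1-fold higher number from compound 1 to compound 4 (0.04 log units; within the scatter) being estimated as no larger than the scatter. Compound 4 is thus estimated at 4000 nM, between 1500 nM and 12000 nM.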

Compound 4, half-maximal inhibitory concentration: 4720 nM
Estimate against measurement, compound 4: 1.2-fold (0.07 log units) below; the measured number falls inside the stated range.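

In this assay, putting 3-chlorophenyl in place of 2-fluorophenyl on the amine nitrogen gives a 1.3-fold higher number from compound 1 to compound 4 (0.11 log units; within the scatter). Within the data shown here, this is the first readable step at this position, since the only earlier step cannot be read. The two aryl groups therefore cannot be told apart here, and no measurement shown accounts for this result.

On these data alone, it remains open whether an unsubstituted phenyl, a benzyl group or a longer alkyl chain on this nitrogen would give a similar number. Also open, as far as these compounds go, is whether a methoxy or hydroxyl group on the phenyl ring would.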